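This account rests on a few compounds, and the source may have more. Where it says the series, first, only, none or still open, it means among the compounds named here.

Three compounds share one core and differ only in the aryl group attached at one aromatic carbon. Compound 1 `Cc1nc2c3ccccc3ccc2c2nc3c(ccc4ccccc43)c(-c3cccc([N+](=O)[O-])c3)c12` carries a 3-nitrophenyl group and, in a functional assay on HCT-116 cells (Homo sapiens) for cytotoxicity, read by MTT assay, with a stated time of 48 h (on this read-out higher numbers stand for weaker inhibition and lower numbers for stronger inhibition), compound 1 gives 13200 nM. Compound 2 `Cc1nc2c3ccccc3ccc2c2nc3c(ccc4ccccc43)c(-c3nccnc3N)c12` has a 3-aminopyrazin-2-yl group at the same place, and compound 2 gives 3560 nM. Compound 3 `Cc1nc2c3ccccc3ccc2c2nc3c(ccc4ccccc43)c(-c3ccccc3S)c12` bears a 2-sulfanylphenyl group, and compound 3 gives 1420 nM, the lowest of the three numbers: the step of a 9.3-fold lower number from compound 1 to compound 3 (0.97 log units; beyond the scatter) and the step of a 2.5-fold lower number from compound 2 to compound 3 (0.40 log units; beyond the scatter) both lie beyond the scatter, so compound 3 stands as the most potent of the measured set.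

Compound 4 `Cc1nc2c3ccccc3ccc2c2nc3c(ccc4ccccc43)c(-c3cc(O)nc4ccccc34)c12` changes this position once more: 2-hydroxyquinolin-4-yl in place of 2-sulfanylphenyl on an aromatic carbon. The 2-hydroxyquinolin-4-yl group enters on an aromatic carbon of a six-membered aromatic ring with 1 nitrogen, part of a fused or bridged system of six rings, opposite the ring nitrogen.

Of the measured steps, a 9.3-fold lower number from compound 1 to compound 3 (0.97 log units; beyond the scatter) and a 2.5-fold lower number from compound 2 to compound 3 (0.40 log units; beyond the scatter) bear on this change, since each swaps the group at the same carbon, and both were modest. The only heteroaromatic substituent so far, in compound 2, gave a higher number than the 2-sulfanylphenyl of compound 3, so a modest rise is expected: the estimated step is a 2.5-fold higher number from compound 3 to compound 4 (0.39 log units; beyond the scatter). Compound 4 is therefore expected to give about 3500 nM, within a range from 900 nM to 14000 nM.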

Compound 4, half-maximal inhibitory concentration: 4630 nM
Estimate against measurement, compound 4: 1.3-fold (0.12 log units) below, within the range that was stated.
By their numbers in this assay, from the lowest: compound 3; then compounds 2 and 4 (each within the scatter of the next); then compound 1.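

In this assay the 2-hydroxyquinolin-4-yl group, with its two rings, does not match the single-ring 2-sulfanylphenyl group, giving a 3.3-fold higher number from compound 3 to compound 4 (0.51 log units; beyond the scatter), and compound 3 remains the most potent of the four. The new group still improves on the 3-nitrophenyl group, with a 2.9-fold lower number from compound 1 to compound 4 (0.45 log units; beyond the scatter), and it cannot be told apart from the 3-aminopyrazin-2-yl group, with a 1.3-fold higher number from compound 2 to compound 4 (0.11 log units; within the scatter), so at this carbon two nitrogen-containing aromatic groups of different size give numbers that lie within the scatter of each other, lower than that of compound 1 and higher than that of compound 3. The data at hand offer no explanation for these differences.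

The compounds shown leave open whether the low number of compound 3 depends on the sulfanyl group itself, a question that a plain phenyl or a 2-hydroxyphenyl group at this carbon could settle. They also leave open what the hydroxy group of compound 4 contributes, which an unsubstituted quinolin-4-yl group would show.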